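Swapping an Amino Group for a Succinimide Ring

A few compounds are considered here, and "the series" means these few. Any claim that something is new, unique, unknown or untested is made for them only; others in the source may bear on it.

Compound 1 `N#Cc1c(-c2ccccc2)cn(-c2ccc(S(=O)(=O)Nc3nccs3)cc2)c1N` carries a free amino group on its core. In a functional assay on HepG2 cells (Homo sapiens) for inhibition, read by sulforhodamine B assay, with a stated time of 24 h (a lower number here means a stronger inhibitor, a higher number a weaker inhibitor), compound 1 gives 5360 nM. Its one measured companion, compound 2 `N#Cc1c(-c2ccccc2)cn(-c2ccc(S(=O)(=O)Nc3ccccn3)cc2)c1N`, gives 5300 nM in this assay, and the step of a 1.0-fold lower number from compound 1 to compound 2 (0.00 log units; within the scatter) concerns only the sulfonamide end of the molecule. Compound 3 `N#Cc1c(-c2ccccc2)cn(-c2ccc(S(=O)(=O)Nc3nccs3)cc2)c1N1C(=O)CCC1=O` differs from compound 1 elsewhere: 2,5-dioxopyrrolidin-1-yl in place of amino on an aromatic carbon. For the measured compounds named here, no measured step touches this part of the core, so nothing anchors the expectation beyond the number for compound 1 itself. For compound 3 the expected step is a 1.2-fold higher number from compound 1 to compound 3 (0.08 log units; within the scatter), giving an estimated value of 6500 nM, within a range from 1500 nM to 28000 nM.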

Compound 3, half-maximal inhibitory concentration: 4560 nM
Beside the measured number, compound 3's estimate is 1.4-fold (0.15 log units) above it; the range from low to high includes it.
By their numbers in this assay, from the lowest: compounds 3, 2 and 1 (each within the scatter of the next).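

In this assay, the step of a 1.2-fold lower number from compound 1 to compound 3 (0.07 log units; within the scatter) stays within the scatter, even though the amino group gives way to the much larger 2,5-dioxopyrrolidin-1-yl. So on this aromatic carbon, the assay reads the two groups alike, and the free amino group is not needed to keep this level of activity. No available evidence explains this result.

Open, from the compounds shown here alone, is whether a smaller acetamide or a carboxylic acid here would read the same. Also open, going by these compounds, is whether 2,5-dioxopyrrolidin-1-yl behaves alike on compound 2.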